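From 4-Methylphenyl to 3-Fluorophenyl on a Shared Acid Chain

The source may hold more compounds than are shown below. What is called first, only, known or untested is meant among the compounds shown, and "the series" means these compounds.

Compound 1 `CC1=C(C)C(=O)C(C(CCCCCCC(=O)O)c2ccccc2)=C(C)C1=O` gives 3200 nM
Compound 2 `CC1=C(C(CCCCCC(=O)O)c2ccccc2)C(=O)c2ccccc2C1=O` gives 240 nM
Compound 3 `CC1=C(C)C(=O)C(C(CCCCCC(=O)O)c2ccc(C)cc2)=C(C)C1=O` gives 1000 nM

In a functional assay (aorta) with Oryctolagus cuniculus as the target (a lower number here means a stronger inhibitor, a higher number a weaker inhibitor), compound 3 reads 1000 nM and so stands in the middle of the three numbers. Compound 1 at 3200 nM lies higher and compound 2 at 240 nM lies lower, and both gaps from compound 3 are beyond the scatter.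

Compound 4 `CC1=C(C)C(=O)C(C(CCCCCC(=O)O)c2cccc(F)c2)=C(C)C1=O` has not yet been measured. It keeps the core and the acid chain of compound 3, and the change is 3-fluorophenyl in place of 4-methylphenyl on a saturated chain carbon bound to a double-bonded ring carbon and a saturated chain carbon in one place only: 3-fluorophenyl in place of 4-methylphenyl on a saturated chain carbon bound to a double-bonded ring carbon and a saturated chain carbon.

Among the compounds with values here, no two measured compounds differ in just one place, so the data give no direct measure of this exchange. The expectation therefore starts from compound 3 at 1000 nM and allows only a small shift toward a lower number in this assay without going beyond the scatter. The estimated step runs a 1.3-fold lower number from compound 3 to compound 4 (0.10 log units; within the scatter) and is expected to stay that small. For compound 4 the estimated value is 800 nM and the expected range runs from 300 nM to 2200 nM before any measurement is at hand.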

Compound 4, half-maximal inhibitory concentration: 1900 nM
For compound 4 the middle estimate is 2.4-fold (0.38 log units) below the measured one; the range from low to high includes it.
By their numbers in this assay, from the lowest: compound 2; then compounds 3, 4 and 1 (each within the scatter of the next, the first and the last beyond it).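

The exchange of 4-methylphenyl for 3-fluorophenyl gives the first one-place comparison among these compounds: in this assay it reads as a 1.9-fold higher number from compound 3 to compound 4 (0.28 log units; within the scatter) and so stays within the usual scatter. On the saturated chain carbon bound to a double-bonded ring carbon and a saturated chain carbon, these two groups therefore cannot be told apart, although they differ in where the ring carries its substituent and in which substituent it carries. Nothing at hand accounts for the size of this step.

Compounds 1 and 2 each differ from compounds 3 and 4 in more than one place, so the separate contributions of the chain and the core cannot be read from them. Going by these compounds, it also remains open whether a phenyl ring carrying a nitrile or a methoxy group at this carbon would give a number outside the scatter of compound 3, and whether an amide in place of the carboxylic acid would keep the number near those of compounds 3 and 4.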